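Working notes: from compound 2 to compound 3

This account rests on a few compounds, and the source may have more. Where it says the series, first, only, none or still open, it means among the compounds named here.

Values in an ADME assay on HepG2 2.2.15 cells (Homo sapiens) for cytotoxicity, read by luminescence, with a stated time of 3 days (a higher number here means that more compound is tolerated, a lower number that less compound is tolerated), so far:
- compound 1 `O=C(Nc1ccc(F)c(Cl)c1)c1ccc(F)c(S(=O)(=O)N2CCCCCC(O)C2)c1` gives 11000 nM
- compound 2 `O=C(Nc1ccc(F)c(Cl)c1)c1ccc(F)c(S(=O)(=O)N2CCOC[C@H](O)C2)c1` gives 19000 nM

Among the compounds with values here, compound 2, with 19000 nM as its number, lies within the scatter of compound 1, the only other compound measured. Compound 3 `O=C(Nc1ccc(F)c(Cl)c1)c1ccc(F)c(S(=O)(=O)N2CCCCC(CO)C2)c1` is still unmeasured. On a sulfonyl sulfur it carries 3-(hydroxymethyl)azepan-1-yl in place of 6-hydroxy-1,4-oxazepan-4-yl, counted as 3-(hydroxymethyl)azepan-1-yl in place of 6-hydroxy-1,4-oxazepan-4-yl on a sulfonyl sulfur while the shared core stays the same.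

Within the data shown here, one measured step bears on this change: a 1.7-fold higher number from compound 1 to compound 2 (0.24 log units; within the scatter) at the same sulfonyl sulfur. The group entering compound 3 matches the group of compound 1 in its heavy-atom count, though not in ring size. Among the measured compounds shown here, with that single step as the only guide, and with no other ring exchange measured, no step beyond the scatter is expected in this assay for this change. The expected step is a 1.6-fold lower number from compound 2 to compound 3 (0.20 log units; within the scatter) on this estimate. Compound 3 is estimated at 12000 nM with 5500 nM to 26000 nM as the expected range.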

Compound 3, half-maximal cytotoxic concentration: 3100 nM
Compound 3: the middle estimate sits 3.9-fold (0.59 log units) above what was measured; measured number below the stated range.
By their numbers in this assay, from the lowest: compound 3; then compounds 1 and 2 (each within the scatter of the next).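

In this assay, within the data shown here, the sulfonyl sulfur position now shows a step beyond the scatter: 3-(hydroxymethyl)azepan-1-yl in place of 6-hydroxy-1,4-oxazepan-4-yl gives a 6.1-fold lower number from compound 2 to compound 3 (0.79 log units; beyond the scatter), whereas the only earlier step at this position stayed within the scatter. Heavy-atom count alone does not set the number here, as the groups of compound 1 and compound 3 have the same count and the same atoms, yet the change gives a 3.5-fold lower number from compound 1 to compound 3 (0.55 log units; beyond the scatter). Nothing measured on these compounds explains either step.

Relative to compound 2, compound 3 gains a ring carbon in place of the ring oxygen, carries hydroxymethyl rather than hydroxy, and has no defined stereocentre, so the compounds shown do not separate these differences. Also open, from the compounds shown here alone, is how the number would respond to an aminomethyl group or a carboxylic acid in place of the hydroxymethyl of 3-(hydroxymethyl)azepan-1-yl, with the shared core unchanged.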